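Swapping the Outer Ring on a Mer Kinase Inhibitor

The source may hold more compounds than are shown below. What is called first, only, known or untested is meant among the compounds shown, and "the series" means these compounds.

Compound 1 `CN(Cc1ccc2nccn2c1)c1nnc(-c2ccc(C3CC3)cc2)o1` gives 794 nM in an assay on isolated protein for inhibition of tyrosine-protein kinase Mer (Homo sapiens), read by LC-MS; on this read-out higher numbers stand for weaker inhibition and lower numbers for stronger inhibition.
Compound 2 `CN(Cc1ccc2nccn2c1)c1nnc(-c2ccc(-c3ccccc3C#N)cc2)o1` gives 25.1 nM in this assay.

Compound 2 has the lowest of the two numbers; its nearest neighbour is compound 1, separated by a 32-fold lower number from compound 1 to compound 2 (1.50 log units; beyond the scatter). Compound 3 `Cc1noc(C)c1-c1ccc(-c2nnc(N(C)Cc3ccc4nccn4c3)o2)cc1` carries 3,5-dimethyl-1,2-oxazol-4-yl in place of 2-cyanophenyl on an aromatic carbon. Going by the values given here, the single measured step bears only loosely on this change: it traded a small saturated ring for an aromatic ring, whereas here one aromatic ring replaces another, para to a large group. A modest rise in the number, within or just beyond the scatter, is expected. For compound 3 the estimate in this assay is 63 nM, ranging from 16 nM to 250 nM, meaning an expected step of a 2.5-fold higher number from compound 2 to compound 3 (0.40 log units; beyond the scatter).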

Compound 3, half-maximal inhibitory concentration: 200 nM
Compound 3: the middle estimate sits 3.2-fold (0.50 log units) below what was measured; the measured number falls inside the stated range.
By their numbers in this assay, from the lowest: compound 2; then compound 3; then compound 1.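

Replacing 2-cyanophenyl with 3,5-dimethyl-1,2-oxazol-4-yl gives an 8.0-fold higher number from compound 2 to compound 3 (0.90 log units; beyond the scatter) in this assay and shows that at this position one aromatic ring cannot simply stand in for another. Even so, an aromatic ring again improves on cyclopropyl, with a 4.0-fold lower number from compound 1 to compound 3 (0.60 log units; beyond the scatter) in this assay and compound 3 falling between the other two. No supporting evidence is available to explain this order. Still open, on these data alone, is whether the nitrile or the six-membered ring accounts for the lower number of compound 2. How a plain phenyl ring, or a phenyl ring carrying an amine or a carboxylic acid, would compare is also unknown.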